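The source may hold more compounds than are shown below. What is called first, only, known or untested is meant among the compounds shown, and "the series" means these compounds.

Measured compounds:
compound 1 `NC1=NC2(CCSCC2)N(OCCCOc2cccc(Cl)c2)C(N)=N1` with 88.3%
compound 2 `NC1=NC2(CCSCC2)N(OCCCOc2cc(Cl)c(Cl)cc2Cl)C(N)=N1` with 84.4%

Both numbers come from an assay on isolated protein for inhibition of Dihydrofolate reductase (Homo sapiens), read by spectrophotometry, using NADPH, with stated times of 5 s and 6 min, tested at 5 uM; on this read-out lower numbers stand for a weaker effect and higher numbers for a stronger effect at the one concentration tested. Within the data shown here, compound 2 gives the lower of the two numbers, but its only neighbour, compound 1, sits a step of a number 3.9 percentage points lower from compound 1 to compound 2 (within the scatter) away, so the two compounds cannot be told apart on these data. That one step belongs to the exchange of 2,4,5-trichlorophenyl for 3-chlorophenyl on an oxygen on a saturated carbon.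

Compound 3 `NC1=NC2(CCSCC2)N(OCCCOc2cccc(Br)c2)C(N)=N1` has not yet been measured in this assay. It differs from compound 2 in one place: 3-bromophenyl in place of 2,4,5-trichlorophenyl on an oxygen on a saturated carbon. Among the measured compounds shown here, this is close to the reverse of the only measured step, since a single halogen on the phenyl ring again replaces three chlorines, with bromine now standing where chlorine stood before. Because that step, a number 3.9 percentage points lower from compound 1 to compound 2 (within the scatter), stayed within the scatter, no step beyond the scatter is expected here either, in either direction.

Compound 3 is therefore expected to give about 87% in this assay, within a range from 77% to 95%, which means an expected step of a number 2.6 percentage points higher from compound 2 to compound 3 (within the scatter).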

Compound 3, a percentage reported as inhibition, at one concentration (the size of the read-out at that concentration, not a potency): 84.2%
Compound 3: middle estimate off by 2.8 percentage points, on the high side; low and high end bracket the measured number.
By their numbers in this assay, from the lowest: compounds 3, 2 and 1 (each within the scatter of the next).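

In this assay the exchange of 2,4,5-trichlorophenyl for 3-bromophenyl on an oxygen on a saturated carbon gives a number 0.2 percentage points lower from compound 2 to compound 3 (within the scatter) and the exchange of chloro for bromo on an aromatic carbon gives a number 4.1 percentage points lower from compound 1 to compound 3 (within the scatter) as its second new reading, so all three compounds now stand within the scatter of one another and cannot be told apart. What the new compound adds is that this place accepts a different halogen as well as a different number of halogens, with a single bromine, a single chlorine and three chlorines on the phenyl ring all giving readings that cannot be separated at the one concentration tested. No measured property is available that could account for this result.

The compounds shown carry only halogens on this phenyl ring, so they leave open how the reading would respond to an amine or a carboxylic acid there, or to a longer chain between the oxygen and the core. Since each reading comes from a single concentration, they also leave open whether the three compounds would differ in potency.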